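Notes on one saturated-oxygen substitution in a cytotoxicity series

The compounds below may be only part of what the source reports. "The series", "measured", "known", "first", "only" and "open" are said of these compounds alone.

Measured in an ADME assay on HEp-2 cells (Homo sapiens) for cytotoxicity, read by MTT assay, with a stated time of 72 h; a higher number here means a weaker inhibitor, a lower number a stronger inhibitor:
compound 1, `COc1ccc(OC)c(C2=C(c3cc(OC)c(OC)c(OC)c3)C(=O)CC2O[SiH2]C(C)(C)C)c1`, gives 19 ug/mL.
compound 2, `COc1ccc(C2=C(c3cc(OC)c(OC)c(OC)c3)CC(O)C2=O)cc1[N+](=O)[O-]`, gives > 100 ug/mL, which is a limit of the assay.
compound 3, `COc1ccc(C2=C(c3cc(OC)c(OC)c(OC)c3)CC(O[SiH2]C(C)(C)C)C2=O)cc1[N+](=O)[O-]`, gives > 100 ug/mL, which is a limit of the assay.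

Going by the values given here, compound 1 is the only compound of the three with a number; the other two values are limits, as stated under (the limit of > 100 ug/mL in this assay, at which 2 of the 3 values shown sit).

Compound 3 and compound 2 differ by one change, (a hydrogen atom in place of a group of 5 heavy atoms (4 carbon, 1 silicon; no ring), on an oxygen on a saturated carbon). The step in this assay is a step that the two limits leave unreadable from compound 3 to compound 2, so the two limits leave the effect of this change unreadable in this pair.

Compound 4, `COc1ccc(OC)c(C2=C(c3cc(OC)c(OC)c(OC)c3)C(=O)CC2O)c1`, has not been measured. It stands to compound 1 as compound 2 stands to compound 3: the change is a hydrogen atom in place of a group of 5 heavy atoms (4 carbon, 1 silicon; no ring), on an oxygen on a saturated carbon, the same change at the same kind of place. How the core of compound 1 differs from the core of compound 3 is not broken down here.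

For the step from compound 1 to compound 4 in this assay the expectation is a 1.3-fold higher number from compound 1 to compound 4 (0.12 log units; within the scatter), a step within the usual scatter; this rests on compound 1 giving a number, 19 ug/mL, while the measured instance of the same change, a step that the two limits leave unreadable from compound 3 to compound 2, gives no readable size, so no direction is taken from it. The estimate for compound 4 in this assay is 25 ug/mL, expected to fall between 8 ug/mL and 80 ug/mL.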

Compound 4, half-maximal inhibitory concentration: > 100 ug/mL
Compound 4: no number, only a limit; the forecaster's own chance of this, stated with the estimate: 25%; middle value at least 4.0-fold (0.60 log units) from the limit.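

In this assay, a hydrogen atom in place of the group of 5 heavy atoms (4 carbon, 1 silicon; no ring), on an oxygen on a saturated carbon, gives an at least 5.2-fold higher number from compound 1 to compound 4 (0.72 log units; beyond the scatter), so on the core of compound 1 this change has a readable effect that lies beyond the scatter. The same change on the other core, linking compound 3 and compound 2, cannot be read, with a limit of the assay at both ends, so the series gives no size for it there and no test of whether the step carries from one core to another. The step on the core of compound 1 also has no upper end, and the series offers little room for reading any difference at the top of the range: the limit of > 100 ug/mL in this assay, at which 3 of the 4 values shown sit.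

Compound 1 gives 19 ug/mL. From the compounds shown here alone, it remains open whether a smaller or different group on the same oxygen, such as a methyl group, an acetyl group or a longer carbon chain, would keep a readable value or would also reach the limit. Going by these compounds, it also remains open whether any group at that oxygen, including one carrying an amine or a carboxylic acid, would bring the core of compound 3 to a readable number in this assay.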